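Compound 2 to the benzylamino compound 4

The source may hold more compounds than are shown below. What is called first, only, known or untested is meant among the compounds shown, and "the series" means these compounds.

- compound 1 `O=C(Nc1[nH]nc(-c2ccccn2)c1C1CC1)c1ccccc1F` gives > 100 mL.min-1.g-1 as a limit
- compound 2 `COc1ccc(C(=O)Nc2[nH]nc(-c3ccccn3)c2C2CC2)cc1` gives > 100 mL.min-1.g-1 as a limit
- compound 3 `O=C(Nc1cc(-c2ccccn2)n[nH]1)N1CCN(c2ccc(F)cc2)CC1` gives 46.5 mL.min-1.g-1 as a number

In an ADME assay on liver (Mesocricetus auratus) for metabolic stability, using microsomes (a higher number here means faster removal of the compound, a lower number slower removal), compound 2 stands at > 100 mL.min-1.g-1 as a limit and not a number. Compound 1 shares that position (the limit of > 100 mL.min-1.g-1 in this assay, at which 2 of the 3 values shown sit). Among the compounds with values here, the only measured step (a step that the two limits leave unreadable from compound 1 to compound 2) therefore offers no size to carry forward.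

Compound 4 `O=C(NCc1ccccc1)Nc1[nH]nc(-c2ccccn2)c1C1CC1` arises by one change (benzylamino in place of 4-methoxyphenyl on a carbonyl carbon), benzylamino in place of 4-methoxyphenyl on a carbonyl carbon. Within the data shown here, the expectation leans toward slower removal only on compound 3, which gives 46.5 mL.min-1.g-1 as the sole number in this assay and is joined to the others by no measured step. The expected step (an at least 1.2-fold lower number from compound 2 to compound 4 (0.09 log units; that floor lies within the scatter)) is modest and may remain unreadable. For compound 4 the estimate is 80 mL.min-1.g-1 (expected range 35 mL.min-1.g-1 to 170 mL.min-1.g-1).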

Compound 4, intrinsic clearance in microsomes: > 400 mL.min-1.g-1
Compound 4: no number, only a limit; the forecaster's own chance of this, stated with the estimate: 40%; at least 5.0-fold (0.69 log units) between middle value and limit.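

In this assay, within the data shown here, compound 1, compound 2 and compound 4 each give only a limit, so no step from compound 1 or compound 2 to compound 4 can be read. Going by these compounds, the size of the change to benzylamino remains open.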